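The source may hold more compounds than are shown below. What is called first, only, known or untested is meant among the compounds shown, and "the series" means these compounds.

Lipophilicity is one of the first properties checked on a new compound, and here only two measurements exist so far. In a physicochemical assay for lipophilicity (a lower number here means a more polar compound, a higher number a more lipophilic compound), compound 2 (`CC(C)(C)c1cc(C(O)CC2CCCCN2)c2ccccc2n1`) gives 2.03, the lower of the two numbers. Compound 1 (`Cc1ccc(Oc2cc(C(O)CC3CCCCN3)c3cc(Cl)ccc3n2)cc1`) gives 3.4, and that gap lies beyond the usual scatter of repeated measurements. The two compounds differ in more than one place, however, so their gap cannot be pinned on any single part of the structure.

Compound 3 (`CC(C)(C)c1cc(C(O)CC2CCCCN2)c2cc(Cl)ccc2n1`) has not yet been measured. It differs from compound 2 in one place only: chloro in place of hydrogen on an aromatic carbon. In words, this is chloro in place of hydrogen on an aromatic carbon. For the measured compounds named here, no measured pair shows this single change on its own, so its size has to be judged. Compound 1 also carries a chloro and stands at 3.4, which offers a weak hint on direction and none on size. The estimated step of a number 0.62 log units higher from compound 2 to compound 3 (beyond the scatter) is expected to go upward, modestly but beyond the scatter. For compound 3 the expected value in this assay is 2.65, with an estimated range from 2.3 to 3.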

Compound 3, partition coefficient: 2.74
The estimate for compound 3 lay 0.09 log units below the measured number; the range from low to high includes it.
By their numbers in this assay, from the lowest: compound 2; then compound 3; then compound 1.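

For the compounds shown here, for the first time, the chloro change stands alone in a measured pair: in this assay, chloro in place of hydrogen on this aromatic carbon, meta to a fused ring and para to a fused ring, gives a number 0.71 log units higher from compound 2 to compound 3 (beyond the scatter). Compound 3 also ties compound 1 into a single-change comparison, since tert-butyl in place of 4-methylphenoxy on an aromatic carbon gives a number 0.66 log units lower from compound 1 to compound 3 (beyond the scatter), so each of the two changes now has a measured size of its own. Nothing available explains the size or direction of either step.

The compounds shown leave open how another group on this carbon, such as fluoro, methoxy or an amine, would move the number, and whether chloro would give a step of similar size on a core carrying 4-methylphenoxy rather than tert-butyl. Each step rests on one pair of compounds, so neither can yet be read as a general pattern for this series.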